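Methylating the amide nitrogen of compound 3

The compounds below may be only part of what the source reports. "The series", "measured", "known", "first", "only" and "open" are said of these compounds alone.

Of the compounds shown here, three have been measured so far in an assay on HEK293F cells for inhibition of cholesterol 24-hydroxylase (Homo sapiens), read by trypan blue exclusion, with stated times of 15 min and 5 h; on this read-out higher numbers stand for weaker inhibition and lower numbers for stronger inhibition. Compound 1 `O=C(NC1CC1)C1CCN(c2cnccc2-c2ccccc2)CC1` gives 8.1 nM, compound 2 `O=C(NC1CC1)C1CCN(c2cnccc2-c2ccccn2)CC1` gives 160 nM, and compound 3 `CNC(=O)C1CCN(c2cncnc2-c2ccccc2)CC1` gives 72 nM. Compound 3 thus stands second highest of the three numbers: its nearest neighbour is compound 2, which lies higher, and the furthest is compound 1, which lies lower, both gaps beyond the scatter. Among the compounds with values here, the one measured single-point step, a 20-fold higher number from compound 1 to compound 2 (1.30 log units; beyond the scatter), concerns the aromatic substituent and not the amide.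

Compound 4 `CN(C)C(=O)C1CCN(c2cncnc2-c2ccccc2)CC1` differs from compound 3 by methyl in place of hydrogen on an amide-type nitrogen, so that methylcarbamoyl becomes dimethylcarbamoyl and the amide hydrogen of compound 3 is lost. Within the data shown here, none of the measured steps touches this part of the molecule, so there is no direct precedent in this assay for what the change will do. The account therefore rests on compound 3 alone and on the general observation that such a change may shift the number in either direction. The step from compound 3 to compound 4 is estimated as a 2.1-fold higher number from compound 3 to compound 4 (0.32 log units; beyond the scatter), with a wide range to reflect the lack of precedent. Compound 4 is expected to give about 150 nM in this assay, between 40 nM and 700 nM.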

Compound 4, half-maximal inhibitory concentration: 16 nM
The estimate for compound 4 lay 9.4-fold (0.97 log units) above the measured number, and the stated range ends above it.
By their numbers in this assay, from the lowest: compounds 1 and 4 (each within the scatter of the next); then compound 3; then compound 2.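

Methyl in place of hydrogen on the amide-type nitrogen gives a 4.5-fold lower number from compound 3 to compound 4 (0.65 log units; beyond the scatter) in this assay, the first measured step at this end of the molecule, since the earlier step concerned only the aromatic substituent. The amide hydrogen of compound 3 is therefore not required for inhibition in this pair: the dimethylcarbamoyl group of compound 4, which has no such hydrogen, gives the lower number, and a single added carbon at this nitrogen is enough to move the result beyond the scatter. Nothing measured here accounts for the size or direction of this step.

The compounds shown leave open whether the trend continues beyond methyl, as an ethyl group or a longer chain on this nitrogen, or the two substituents joined into a pyrrolidine ring, could either extend the change or reverse it. On these data alone, it also remains open whether methyl on the amide-type nitrogen would have a similar effect in the cyclopropyl amides, compound 1 and compound 2, whose aromatic parts differ from that of compound 3.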